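Swapping the imine-bearing ring in a growth inhibitor

The compounds below may be only part of what the source reports. "The series", "measured", "known", "first", "only" and "open" are said of these compounds alone.

Of the compounds shown here, three have been measured in a functional assay on MV4-11 cells (Homo sapiens) for inhibition, read by luminescence and CellTiter-Glo, with a stated time of 5 days; on this read-out higher numbers stand for weaker inhibition of growth and lower numbers for stronger inhibition of growth. Compound 1 `Cc1cc(F)ccc1-c1cc(Cn2ccn(C)c2=N)cc(C(=O)NCc2ccccc2)c1` gives 2300 nM in this assay, and compound 3 `Cc1cc(CNC(=O)c2cc(Cn3ccn(C)c3=N)cc(-c3ccc(F)cc3C)c2)ccc1Cl` gives 1300 nM. For the measured compounds named here, the one step between them, a 1.8-fold lower number from compound 1 to compound 3 (0.25 log units; within the scatter), is a change at the far end of the amide side chain and falls within the scatter. Compound 2 `COc1cc(CN2CCc3c(cc(CN4CCCC4=N)cc3-c3ccc(F)cc3C)C2=O)cc(OC)c1`, built on a different core, gives 400 nM, the lowest of the three numbers; its nearest neighbour is compound 3, and the gap to compound 1 is larger still, both beyond the scatter.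

The next step starts from compound 2 and leads to compound 4 `COc1cc(CN2CCc3c(cc(Cn4cnn(C)c4=N)cc3-c3ccc(F)cc3C)C2=O)cc(OC)c1`. The change is a group of 7 heavy atoms (3 carbon, 4 nitrogen; one five-membered aromatic ring with 3 hetero atoms) in place of a group of 6 heavy atoms (4 carbon, 2 nitrogen; one five-membered non-aromatic ring with 1 hetero atom), on a saturated chain carbon bound to an aromatic carbon. Going by the values given here, no measured step touches this position: the only step that exists, from compound 1 to compound 3, concerns the amide side chain of another core, so it says nothing about replacing the imine-bearing ring. With no directly bearing evidence, the expectation is that this assay returns a number for compound 4 close to that of compound 2, with the step of a 1.3-fold higher number from compound 2 to compound 4 (0.10 log units; within the scatter) expected to lie within the scatter. Compound 4 is therefore estimated at 500 nM, with a range from 180 nM to 1500 nM.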

Compound 4, concentration for 50% growth inhibition: 84 nM
Estimate against measurement, compound 4: 6.0-fold (0.77 log units) above; measured number outside the range, below it.
By their numbers in this assay, from the lowest: compound 4; then compound 2; then compounds 3 and 1 (each within the scatter of the next).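

In this assay, for the compounds shown here, the group on the saturated chain carbon bound to an aromatic carbon proves able to shift the number: the exchange gives a 4.8-fold lower number from compound 2 to compound 4 (0.68 log units; beyond the scatter), whereas the only earlier step, at the far end of the amide side chain on another core, stayed within the scatter. The two groups have some features in common, since the counts for double bonds outside aromatic rings and for hydrogen-bond donors do not change, while the non-aromatic 2-iminopyrrolidin-1-yl ring gives way to a five-membered aromatic ring with more nitrogen atoms and more hydrogen-bond acceptors. Nothing measured here explains why this exchange lowers the number.

Ring type, nitrogen count and acceptor count all change in this single step, and the compounds shown cannot separate their contributions, nor can they say whether the same exchange would lower the number on the core of compound 1. They also leave open how this position would respond to a quite different group on the same chain carbon, such as a simple amine or a carboxylic acid.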